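A few compounds are considered here, and "the series" means these few. Any claim that something is new, unique, unknown or untested is made for them only; others in the source may bear on it.

In a functional assay on BT-474 cells (Homo sapiens) for inhibition, read by fluorescence, with a stated time of 72 h (on this read-out lower numbers stand for stronger inhibition of growth and higher numbers for weaker inhibition of growth), compound 1 `CCCCn1cnc2c(NCc3cccc(Cl)c3)nc(N[C@H]3CC[C@H](N)CC3)nc21` gives 4700 nM and compound 2 `CC(C)CCn1cnc2c(NCc3cccc(Cl)c3)nc(N[C@H]3CC[C@H](N)CC3)nc21` gives 6600 nM while compound 3 `CCCCn1cnc2c(Nc3cccc(Cl)c3)nc(N[C@H]3CC[C@H](N)CC3)nc21` gives 5100 nM in the same range. Compound 2 thus stands within the scatter of both others. Next is compound 4 `CC(C)CCn1cnc2c(Nc3cccc(O)c3)nc(N[C@H]3CC[C@H](N)CC3)nc21` with the change 3-hydroxyphenyl in place of 3-chlorobenzyl on a nitrogen on an aromatic ring read as 3-hydroxyphenyl in place of 3-chlorobenzyl on a nitrogen on an aromatic ring. The closest measured step is a 1.1-fold higher number from compound 1 to compound 3 (0.04 log units; within the scatter) for 3-chlorophenyl in place of 3-chlorobenzyl. The chain step a 1.4-fold higher number from compound 1 to compound 2 (0.15 log units; within the scatter) also stays within the scatter. For the measured compounds named here, no measured compound carries 3-hydroxyphenyl, so the range stays wide. The expected step is a 1.7-fold lower number from compound 2 to compound 4 (0.22 log units; within the scatter) and thus none beyond the scatter in this assay on present data. The estimated value for compound 4 is 4000 nM with an expected range of 1000 nM to 12000 nM for now.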

Compound 4, concentration for 50% growth inhibition: 14700 nM
Compound 4: the middle estimate sits 3.7-fold (0.57 log units) below what was measured; the measured number lies above the stated range.
By their numbers in this assay, from the lowest: compounds 1, 3 and 2 (each within the scatter of the next); then compound 4.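

In this assay, for the compounds shown here, 3-hydroxyphenyl in place of 3-chlorobenzyl on this nitrogen gives the only step so far beyond the scatter, a 2.2-fold higher number from compound 2 to compound 4 (0.35 log units; beyond the scatter), a modest one. The exchange for 3-chlorophenyl stayed within the scatter at a 1.1-fold higher number from compound 1 to compound 3 (0.04 log units; within the scatter), so this position does respond to some changes, although that pair carries a different chain. Nothing at hand bears on the cause of the step.

On these data alone, the change swaps the chlorine for a hydroxyl and removes the benzyl carbon together, so their separate shares stay open. A 3-hydroxybenzyl or 3-aminophenyl group on this nitrogen would help separate them.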